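A few compounds are considered here, and "the series" means these few. Any claim that something is new, unique, unknown or untested is made for them only; others in the source may bear on it.

Measured so far:
compound 1 `CC#C[C@H]1CN(S(=O)(=O)c2ccc(N)nc2)CCN1c1ccc([C@@](O)(CO)C(F)(F)F)cc1` — 89 nM
compound 2 `CC#C[C@H]1CN(S(=O)(=O)c2ccc(N)nc2)CCN1c1ncc(C(O)(C(F)(F)F)C(F)(F)F)s1` — > 12500 nM, which is a limit of the assay and not a number

Both compounds were tested in an assay on cells (Hepatocyte) for inhibition of glucokinase regulatory protein (Mus musculus), with stated times of 20 min and 40 min; on this read-out higher numbers stand for an effect only at larger amounts of compound and lower numbers for an effect already at smaller amounts. Going by the values given here, compound 1 holds the only number given; the other entry sits at the limit of > 12500 nM in this assay, at which 1 of the 2 values shown sits, so compound 1 cannot be ranked against anything, only taken as the one starting point with a real value.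

Compound 3 `CC#C[C@H]1CN(S(=O)(=O)c2ccc(N)nc2)CCN1c1ccc(S(=O)(=O)Nc2ccccc2)cc1` shares the core of compound 1 and differs from it in one spot: a group of 10 heavy atoms (6 carbon, 1 nitrogen, 2 oxygen, 1 sulfur; one six-membered aromatic ring of carbon only) in place of a group of 8 heavy atoms (3 carbon, 2 oxygen, 3 fluorine; no ring), on an aromatic carbon. Among the compounds with values here, no measured pair showing a change of this kind exists, so the size of the step can only be guessed. Because compound 2 sits at the limit of > 12500 nM in this assay, at which 1 of the 2 values shown sits, while carrying a different side group together with a different ring, it cannot say what this single swap does.

The swap is large, and a loss of effect is expected rather than a gain; the step from compound 1 to compound 3 is estimated at an 11-fold higher number from compound 1 to compound 3 (1.05 log units; beyond the scatter). Compound 3 is therefore expected to give about 1000 nM in this assay, with a range from 150 nM to 12500 nM.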

Compound 3, half-maximal effective concentration: > 12500 nM
Compound 3: a limit, no number (the forecaster's own chance of this, stated with the estimate: 25%); at least 12-fold (1.09 log units) between middle value and limit.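

In this assay compound 3 gives > 12500 nM, which is a limit of the assay and not a number. Putting phenylsulfamoyl on this aromatic carbon, para to a large group, in place of the group of 8 heavy atoms gives an at least 140-fold higher number from compound 1 to compound 3 (2.14 log units; beyond the scatter), so this position on the shared core does not tolerate every large group, and the change here is far from neutral. Because that step is measured against a limit, it gives only the smallest possible size of the change, and the assay offers no way of ranking the compounds at its limit: the limit of > 12500 nM in this assay, at which 2 of the 3 values shown sit.

From the compounds shown here alone, what remains open is whether the effect comes from losing the group of compound 1 or from adding phenylsulfamoyl, since this one swap does both at once. A small group on the same aromatic carbon, such as an amine or a carboxylic acid, or a plain sulfonamide without the phenyl ring, would be needed to tell these two readings apart.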